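Cinnamamide series: aryl change on the sulfur, compound 2 to 4

The compounds below may be only part of what the source reports. "The series", "measured", "known", "first", "only" and "open" are said of these compounds alone.

Compound 2 `Nc1ccccc1NC(=O)/C=C/c1ccc(CSc2ccc(F)cc2)cc1` gives 20.2% in a functional assay on HCT-116 cells (Homo sapiens) for inhibition, read by CCK-8 assay, with a stated time of 72 h, tested at 8 uM; a lower number here means less inhibition of growth, a higher number more inhibition of growth at the concentration tested. Among the three numbers known so far it is the lowest: compound 3 `Nc1ccccc1NC(=O)c1ccc(CSc2ccc(C(F)(F)F)cn2)cc1` gives 25.8%, which lies within the scatter of compound 2, while compound 1 `COc1ccc(SCc2ccc(/C=C/C(=O)Nc3ccccc3N)cc2)cc1OC` gives 49.5%, beyond the scatter. Compound 4 `Cc1cc(C)cc(SCc2ccc(/C=C/C(=O)Nc3ccccc3N)cc2)c1` is the next member, not yet measured in this assay; it differs from compound 2 by 3,5-dimethylphenyl in place of 4-fluorophenyl on a sulfur.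

Within the data shown here, only one measured step bears on this position: the step from compound 1 to compound 2, a number 29.3 percentage points lower from compound 1 to compound 2 (beyond the scatter), which shows that a change of the aryl on the sulfur can move this assay by a modest amount. That step went from a ring carrying two substituents to one carrying a single fluorine; compound 4 returns to a ring with two substituents, though methyl rather than methoxy, so a partial move back upward is expected, but of uncertain size. For compound 4 the expected step is a number 11.8 percentage points higher from compound 2 to compound 4 (beyond the scatter). Compound 4 is therefore estimated at 32%, with a range from 15% to 50%.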

Compound 4, percent growth inhibition at one concentration: 4.2%
Compound 4: the middle estimate sits 27.8 percentage points above what was measured; the measured number lies below the stated range.
By their numbers in this assay, from the lowest: compound 4; then compounds 2 and 3 (each within the scatter of the next); then compound 1.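

In this assay, the move to a ring with two methyl groups goes down rather than up, a number 16 percentage points lower from compound 2 to compound 4 (beyond the scatter) and a number 45.3 percentage points lower from compound 1 to compound 4 (beyond the scatter), so two substituents on the aryl do not by themselves carry the higher number of compound 1. Among these compounds, the aryl on the sulfur thus spreads the three cinnamamides over a wider span than the single earlier step showed, with 3,4-dimethoxyphenyl at the top, 4-fluorophenyl in the middle and 3,5-dimethylphenyl at the bottom, each separated beyond the scatter. No measurement at hand offers an explanation for this order.

Between compound 1 and compound 4, the substituent type and the substitution pattern both change, so their contributions cannot be separated here. As far as these compounds go, how an aryl carrying an amine or a carboxylic acid on this sulfur would read in this assay remains open.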